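Working notes: amide variation at the carbonyl, compounds 2 and 3

The source may hold more compounds than are shown below. What is called first, only, known or untested is meant among the compounds shown, and "the series" means these compounds.

Of the compounds shown here, two carry numbers so far. Compound 1 `O=C(O)COc1ccncc1-c1ccc2ccccc2c1` gives 16% in an assay on a protein complex for inhibition of CDK8/Cyclin C (Homo sapiens), with a stated time of 1 h, tested at 10 uM; a lower number here means less inhibition, a higher number more inhibition at the concentration tested (going by the name of the read-out). Compound 2 `O=C(/C=C/c1ccncc1-c1ccc2ccccc2c1)N1CCOCC1` gives 99% in this assay; this is the higher of the two numbers, and its gap to compound 1 lies beyond the scatter. Among the measured compounds shown here, no pair differing in a single place has been measured, so no size of step is known. Compound 3 `NC(=O)/C=C/c1ccncc1-c1ccc2ccccc2c1` is not yet measured. It differs from compound 2 as follows: amino in place of morpholin-4-yl on a carbonyl carbon. Because compound 2 already gives 99%, close to the top of the read-out, an upward move for compound 3 is hardly possible; a modest downward step is expected, which may still fall within the scatter. Compound 3 is expected to give 85%, with a range from 55% to 99%. The expected step of a number 14 percentage points lower from compound 2 to compound 3 (beyond the scatter) is small and downward.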

Compound 3, a percentage reported as inhibition, at one concentration (the size of the read-out at that concentration, not a potency): 102%
Beside the measured number, compound 3's estimate is 17 percentage points below it, and the stated range ends below it.
By their numbers in this assay, from the lowest: compound 1; then compounds 2 and 3 (each within the scatter of the next).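

In this assay, amino in place of morpholin-4-yl on the carbonyl carbon gives a number 3 percentage points higher from compound 2 to compound 3 (within the scatter), so the number stays level without the six-membered ring, although a single concentration this close to the top of the read-out cannot separate potencies. On the aromatic carbon, 2-carbamoylethenyl in place of carboxymethoxy gives a number 86 percentage points higher from compound 1 to compound 3 (beyond the scatter), the first large step read between compounds differing in one place. No measured evidence is available to explain either step.

The compounds shown leave open whether methylamino or hydroxy on the same carbonyl carbon would keep the read-out near the top. They also leave open whether a saturated ethyl chain could replace the ethenyl link in the 2-carbamoylethenyl group.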